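This account rests on a few compounds, and the source may have more. Where it says the series, first, only, none or still open, it means among the compounds named here.

Measured compounds in a functional assay on KB cells (Homo sapiens) for cytotoxicity, read by MTT assay, with a stated time of 48 h; a higher number here means a weaker inhibitor, a lower number a stronger inhibitor:

Compound 1, `CCn1cc(-c2nc3ccccc3o2)c(=O)c2cc(F)c(N3CCNC(C)C3)c(F)c21`: 18900 nM
Compound 2, `CCn1cc(-c2nc3ccccc3s2)c(=O)c2cc(F)c(N3CCNCC3)cc21`: 28700 nM
Compound 3, `CCn1cc(-c2nc3ccc([N+](=O)[O-])cc3o2)c(=O)c2cc(F)c(N3CCNC(C)C3)c(F)c21`: 600 nM

Compound 1 and compound 3 differ in one place only: nitro in place of hydrogen on an aromatic carbon. This single change produced a 32-fold lower number from compound 1 to compound 3 (1.50 log units; beyond the scatter), so compound 3 inhibits the cells far more strongly than compound 1. Compound 2 has a different core from compound 1; the difference between the two cores is not broken down here. The values of compound 1 and compound 2 in this assay lie close together, so nothing can be said about which of the two is the stronger.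

Compound 4, `CCn1cc(-c2nc3ccc([N+](=O)[O-])cc3s2)c(=O)c2cc(F)c(N3CCNCC3)cc21`, has not yet been measured. It is related to compound 2 in the same way that compound 3 is related to compound 1: nitro in place of hydrogen on an aromatic carbon, at the same kind of position on the ring. Because the same change gave a 32-fold lower number from compound 1 to compound 3 (1.50 log units; beyond the scatter) on the core of compound 1, a step of similar size is expected here, estimated at a 29-fold lower number from compound 2 to compound 4 (1.46 log units; beyond the scatter). Starting from the value of compound 2, compound 4 is expected to give about 1000 nM in this assay, most likely between 300 nM and 4000 nM. This rests on a single earlier step, so the range is kept wide.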

Compound 4, half-maximal inhibitory concentration: 700 nM
Compound 4: the middle estimate sits 1.4-fold (0.15 log units) above what was measured; measured number inside the range.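

In this assay, adding a nitro group gave a 41-fold lower number from compound 2 to compound 4 (1.61 log units; beyond the scatter) on the second core. Set beside the earlier step, the change carried over from one core to the other with its size intact: the same change on two cores in this assay, a 32-fold lower number (1.50 log units; beyond the scatter) from compound 1 to compound 3 and a 41-fold lower number (1.61 log units; beyond the scatter) from compound 2 to compound 4, 1.3-fold (0.11 log units) apart, within the scatter of two such steps. Within the data shown here, this rests on only two matched pairs, so it does not show that the step would hold on a further core, and it does not explain why adding the nitro group lowers the number.

The compounds shown carry only hydrogen or nitro at this aromatic carbon, so it remains open whether another group there, such as an amine, a nitrile or a carboxylic acid, would lower the number as far. From the compounds shown here alone, it also remains open whether a nitro group on a different carbon of the same ring would give a step of similar size.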